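A few compounds are considered here, and "the series" means these few. Any claim that something is new, unique, unknown or untested is made for them only; others in the source may bear on it.

Among the measured compounds shown here, compound 1 `CN(C)c1ccc(/C=C2\CCC/C(=C\c3ccccc3[N+](=O)[O-])C2=O)cc1` gives 168000 nM in a functional assay on CCRF-CEM cells (Homo sapiens) for cytotoxicity, with a stated time of 72 h (a higher number here means a weaker inhibitor, a lower number a stronger inhibitor), the highest of the three numbers measured so far. Compound 2 `COc1ccc(/C=C2\CCC/C(=C\c3ccccc3[N+](=O)[O-])C2=O)cc1` gives 7450 nM in this assay, and compound 3 `O=C1/C(=C/c2ccccc2)CCC/C1=C\c1ccccc1[N+](=O)[O-]` gives 925 nM. All three measured steps change the group on the same ring of the shared core: a 23-fold lower number from compound 1 to compound 2 (1.35 log units; beyond the scatter), a 180-fold lower number from compound 1 to compound 3 (2.26 log units; beyond the scatter) and an 8.1-fold lower number from compound 2 to compound 3 (0.91 log units; beyond the scatter). Compound 1 thus stands at the top of the series, separated from both other compounds by gaps beyond the scatter.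

Compound 4 `CN(C)c1ccc(/C=C2\CCC/C(=C\c3cccc([N+](=O)[O-])c3)C2=O)cc1` keeps the dimethylamino of compound 1 and differs on the nitro-bearing ring: 3-nitrophenyl in place of 2-nitrophenyl on a double-bonded chain carbon bound to a double-bonded ring carbon. For the measured compounds named here, none of the measured steps touches that ring; each of them swaps dimethylamino, methoxy or hydrogen on the other ring. Going by the values given here, no measured step therefore bears directly on the step from compound 1 to compound 4, and its size cannot be read from the series. With nothing to anchor a shift, the expectation is a number close to that of compound 1. The step of a 1.3-fold lower number from compound 1 to compound 4 (0.11 log units; within the scatter) is estimated to stay within the scatter, with a wide range allowed either way. Compound 4 is estimated at 130000 nM in this assay, expected to fall between 30000 nM and 550000 nM.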

Compound 4, half-maximal inhibitory concentration: 11700 nM
For compound 4 the middle estimate is 11-fold (1.05 log units) above the measured one; measured number below the stated range.
By their numbers in this assay, from the lowest: compound 3; then compounds 2 and 4 (each within the scatter of the next); then compound 1.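

In this assay, among the compounds shown here, 3-nitrophenyl in place of 2-nitrophenyl on a double-bonded chain carbon bound to a double-bonded ring carbon gives a 14-fold lower number from compound 1 to compound 4 (1.16 log units; beyond the scatter), so the nitro-bearing ring is a second place in the molecule where a change moves the number, which the earlier steps on the other ring could not show. The two groups have the same atoms and the same counts, so this step rearranges the atoms of the group without adding or removing any, and with the dimethylamino held constant it is still large. Nothing available explains why this rearrangement shifts the number by this much.

The compounds shown leave open whether 3-nitrophenyl in place of 2-nitrophenyl gives a step of similar size when methoxy or hydrogen replaces the dimethylamino on the other ring. They also leave open how the number responds when a nitrile, an amine or a carboxylic acid stands in place of the nitro group on that ring.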